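This account rests on a few compounds, and the source may have more. Where it says the series, first, only, none or still open, it means among the compounds named here.

Working notes on the series. Compound 1 `CCN(CC)C/C1=C/C[C@](C)(CCC=C(C)C)/C=C/[C@@H](OC(=O)C=C(C)C)[C@](C)(O)/C=C/C1=O` is tested in a functional assay on A549 cells (Homo sapiens) for antiproliferative activity, read by MTT assay, with a stated time of 48 h (on this read-out lower numbers stand for stronger inhibition and higher numbers for weaker inhibition), where compound 1 gives 130 nM. Compound 2 `CC(C)=CCC[C@]1(C)/C=C/[C@@H](OC(=O)C=C(C)C)[C@](C)(O)CCC(=O)/C(CO)=C\C1` shows in this assay only a limit of the assay, namely > 40000 nM. For the measured compounds named here, compound 1 thus stands as the only numerical value shown in this assay. The remaining entry is the limit of > 40000 nM in this assay, at which 1 of the 2 values shown sits, and it belongs to compound 2. No step between two measured compounds that differ in one place is available, so nothing is said here about a cause for the gap between compound 1 and compound 2.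

Compound 3 `CC(C)=CCC[C@]1(C)/C=C/[C@@H](OC(=O)C=C(C)C)[C@](C)(O)/C=C/C(=O)/C(C(=O)N2CCCC2)=C\C1` has not yet been measured in this assay. It differs from compound 1 as follows: (pyrrolidin-1-yl)carbonyl in place of (diethylamino)methyl on a double-bonded ring carbon. Going by the values given here, with no measured step to rest on, the expectation for compound 3 is drawn from compound 1 alone, and a weakening of modest size is expected, namely a 3.8-fold higher number from compound 1 to compound 3 (0.59 log units; beyond the scatter), though a change within the scatter cannot be excluded. Compound 3 is accordingly estimated at 500 nM in this assay, with a range from 100 nM to 3000 nM.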

Compound 3, half-maximal inhibitory concentration: 13000 nM
Estimate against measurement, compound 3: 26-fold (1.41 log units) below; measured number above the stated range.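

In this assay, for the compounds shown here, this double-bonded ring carbon proves far from indifferent to its substituent: replacing (diethylamino)methyl with (pyrrolidin-1-yl)carbonyl gives a 100-fold higher number from compound 1 to compound 3 (2.00 log units; beyond the scatter), the first direct reading at this place on the core of compound 1. The large step comes with no difference in the counted hydrogen-bond donors, hydrogen-bond acceptors or net charge, so these counts do not separate the two groups, whereas the entering group has a carbonyl and a five-membered non-aromatic ring that the leaving group lacks. Nothing measured here bears on the cause of this step.

The single step changes the carbonyl and the ring together, so the compounds shown leave open which of the two differences carries the loss. A (pyrrolidin-1-yl)methyl group or a (diethylamino)carbonyl group at the same ring carbon would separate the two, and a primary amine on a one-carbon link would show whether the diethyl substitution matters at this place.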